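A Dichlorophenyl Swap and Cell Tolerance

The source may hold more compounds than are shown below. What is called first, only, known or untested is meant among the compounds shown, and "the series" means these compounds.

- Compound 1 `O=C1/C(=C/c2ccc(Cl)cc2)CCC/C1=C\c1ccc(Cl)cc1` gives 32100 nM as measured
- Compound 2 `COc1cccc(/C=C2\CCC/C(=C\c3ccccc3)C2=O)c1OC` gives 33500 nM as measured

Both numbers come from an ADME assay on Vero cells (Chlorocebus sabaeus) for inhibition (a lower number here means that less compound is tolerated, a higher number that more compound is tolerated), and they show how much compound the cells tolerate. Compound 2 stands level with compound 1, since their two values lie within the usual scatter of each other. Compound 3 `COc1cccc(/C=C2\CCC/C(=C\c3c(Cl)cccc3Cl)C2=O)c1OC` carries 2,6-dichlorophenyl in place of phenyl on a double-bonded chain carbon bound to a double-bonded ring carbon. Going by the values given here, no two measured compounds differ in one place only, so the evidence for this step is thin. Compound 1 also carries chlorine and gives 32100 nM in this assay with no gap beyond the scatter to compound 2. The expected step of a 1.2-fold lower number from compound 2 to compound 3 (0.08 log units; within the scatter) is a slight fall in the number that stays within the scatter. The estimate for compound 3 is 28000 nM with an expected range of 12000 nM to 65000 nM as the likely span.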

Compound 3, half-maximal cytotoxic concentration: 160000 nM
Compound 3: middle estimate off by 5.7-fold (0.76 log units), on the low side; measured number above the stated range.
By their numbers in this assay, from the lowest: compounds 1 and 2 (each within the scatter of the next); then compound 3.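

In this assay, placing 2,6-dichlorophenyl in place of phenyl on a double-bonded chain carbon bound to a double-bonded ring carbon gives a 4.8-fold higher number from compound 2 to compound 3 (0.68 log units; beyond the scatter) and so shows that the cells tolerate more of compound 3. Going by these compounds alone, this is the first change in one place only, and it shows that what sits at this position can move the number beyond the scatter. The data shown offer nothing that explains this rise.

On these data alone, the result rests on a single pair of compounds, so it remains unknown whether the rise needs both chlorine atoms or whether one would do. As far as these compounds go, it is also open whether a different group at the same position, such as two fluorine atoms, an amine or a carboxylic acid on that ring, would move the number in the same direction.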